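Removing a Methyl: Compound 2 to Compound 3

A few compounds are considered here, and "the series" means these few. Any claim that something is new, unique, unknown or untested is made for them only; others in the source may bear on it.

Of the compounds shown here, two have been measured so far. Compound 1 `O=C1Nc2ccccc2[C@]12N[C@H](c1ccccc1)[C@H](c1ccccc1)[C@@]21CCc2c([nH]c3ccccc23)C1=O` and compound 2 `COc1ccc([C@H]2[C@@H](c3ccccc3)N[C@@]3(C(=O)Nc4ccccc43)[C@]23CCc2c([nH]c4ccc(C)cc24)C3=O)cc1` share a core and differ from each other in two places. In a functional assay on A549 cells (Homo sapiens) for antiproliferative activity, read by MTT assay, with a stated time of 48 h (a lower number here means a stronger inhibitor, a higher number a weaker inhibitor), compound 1 gives 17000 nM. In this assay compound 2 gives 20000 nM. Compound 2 thus holds the highest of the two numbers, but its gap to compound 1 lies within the usual scatter, so the two readings cannot be told apart. Among the compounds with values here, no pair of measured compounds differs in only one place, so the measurements alone say nothing about what any single change does.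

Compound 3 `COc1ccc([C@H]2[C@@H](c3ccccc3)N[C@@]3(C(=O)Nc4ccccc43)[C@]23CCc2c([nH]c4ccccc24)C3=O)cc1` is not yet measured. It differs from compound 2 by a single change, (hydrogen in place of methyl on an aromatic carbon), hydrogen in place of methyl on an aromatic carbon. Compound 1 lacks this same methyl, yet also differs in another place, and in this assay compound 1 gives 17000 nM, a reading within the scatter of compound 2. This change is therefore expected to give a 1.1-fold lower number from compound 2 to compound 3 (0.05 log units; within the scatter), a step no larger than the scatter. Compound 3 is expected to give 18000 nM, with a range from 9000 nM to 40000 nM.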

Compound 3, half-maximal inhibitory concentration: 21000 nM
Compound 3: middle estimate off by 1.2-fold (0.07 log units), on the low side; low and high end bracket the measured number.
By their numbers in this assay, from the lowest: compounds 1, 2 and 3 (each within the scatter of the next).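

In this assay the measured compounds can now be compared one change at a time, and hydrogen in place of methyl on an aromatic carbon gives a 1.1-fold higher number from compound 2 to compound 3 (0.02 log units; within the scatter) with the step lying within the scatter, so the methyl at this position, on a six-membered aromatic ring of carbon only, makes no readable difference to the number. The second pair, for methoxy in place of hydrogen on an aromatic carbon, gives a 1.2-fold higher number from compound 1 to compound 3 (0.09 log units; within the scatter) and is also within the scatter, so neither single change separates its two compounds. Nothing measured here offers an explanation for either result.

Both changes shown are limited to a methyl or a methoxy set against hydrogen, and all three compounds stand within the scatter of one another, so these results cannot show whether this position is indifferent to its substituent in general. An amine, a carboxylic acid or a chlorine atom on the same aromatic carbon remains an open case, as does a hydroxyl group in place of the methoxy.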